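The source may hold more compounds than are shown below. What is called first, only, known or untested is meant among the compounds shown, and "the series" means these compounds.

In a functional assay on NB1 cells (Homo sapiens) for cytotoxicity, read by MTT assay, with a stated time of 3 days (a lower number here means a stronger inhibitor, a higher number a weaker inhibitor), compound 1 `N#Cc1c(Cl)nc(SCc2nc3ccccc3[nH]2)nc1-c1ccccc1` gives 2.87 nM. Compound 2 `N#Cc1c(NN)nc(SCc2nc3ccccc3[nH]2)nc1-c1ccccc1` gives 5.4 nM and compound 3 `CNc1nc(SCc2nc3ccccc3[nH]2)nc(-c2ccccc2)c1C#N` gives 4.46 nM, so that the three numbers sit close together: a 1.9-fold higher number from compound 1 to compound 2 (0.27 log units; within the scatter), a 1.6-fold higher number from compound 1 to compound 3 (0.19 log units; within the scatter) and a 1.2-fold lower number from compound 2 to compound 3 (0.08 log units; within the scatter). Compound 1 therefore stands among three values that cannot be told apart.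

Compound 4 `N#Cc1c(Nc2ccccn2)nc(SCc2nc3ccccc3[nH]2)nc1-c1ccccc1` differs from compound 1 in one place: (pyridin-2-yl)amino in place of chloro on an aromatic carbon.

Two of the measured steps bear on this change, since both also replace the chloro on that same aromatic carbon with a nitrogen-linked group: the step from compound 1 to compound 2 and the step from compound 1 to compound 3, both of which stayed within the scatter. Neither of those groups carries a ring, however, and the (pyridin-2-yl)amino group is considerably larger, so the two steps offer only a loose guide. On their evidence the expectation for this assay is a step of about a 1.7-fold higher number from compound 1 to compound 4 (0.24 log units; within the scatter), which is to say no change beyond the scatter, with a broad range to allow for the larger group. Compound 4 is accordingly estimated at 5 nM, somewhere between 1.5 nM and 20 nM.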

Compound 4, half-maximal inhibitory concentration: 3.9 nM
Compound 4: the middle estimate sits 1.3-fold (0.11 log units) above what was measured; the range from low to high includes it.
By their numbers in this assay, from the lowest: compounds 1, 4, 3 and 2 (each within the scatter of the next).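

In this assay, within the data shown here, the aromatic carbon next to the ring nitrogen and ortho to a cyano group takes (pyridin-2-yl)amino, with its seven heavy atoms and one six-membered aromatic ring, in place of the single chlorine without a step beyond the scatter (a 1.4-fold higher number from compound 1 to compound 4 (0.13 log units; within the scatter)). The earlier compounds had shown this only for nitrogen-linked groups without a ring, so the tolerance seen at this position now extends to one ring-bearing group. On the nitrogen itself, pyridin-2-yl cannot be told apart from methyl (a 1.1-fold lower number from compound 3 to compound 4 (0.06 log units; within the scatter)) or from amino (a 1.4-fold lower number from compound 2 to compound 4 (0.14 log units; within the scatter)), and nothing available explains why these values stay so close.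

Among these compounds, no step among the four compounds lies beyond the scatter, so it remains open which change at this carbon, if any, would move the number in this assay. From the compounds shown here alone, whether a carboxylic acid, a methoxy group, a morpholine ring or a longer alkylamine chain there would stay within the scatter is also open, as is whether pyridin-3-yl or plain phenyl on the nitrogen would read like pyridin-2-yl.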